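A Larger Fluorinated Group in Place of Trifluoromethyl

A few compounds are considered here, and "the series" means these few. Any claim that something is new, unique, unknown or untested is made for them only; others in the source may bear on it.

Compound 1 `Oc1noc2cccc(Nc3cccc(C(F)(F)F)c3)c12` is the reference point of this account. In an ADME assay on isolated protein for inhibition of cytochrome c oxidase subunit 2 (Homo sapiens), read by ELISA, tested at 100 uM (on this read-out higher numbers stand for more inhibition at the one concentration tested (going by the name of the read-out) and lower numbers for less inhibition), compound 1 gives 13%, the highest of the three numbers measured. Its isomer compound 2 `Oc1noc2ccc(Nc3cccc(C(F)(F)F)c3)cc12` gives 0% in this assay, and compound 3 `Oc1noc2cccc(Nc3cc(C(F)(F)F)cc(C(F)(F)F)c3)c12` gives 0%. For the measured compounds named here, the only single-change step among the measured compounds is a number 13 percentage points lower from compound 1 to compound 3 (beyond the scatter), a modest fall beyond the scatter. Compound 4 `Oc1noc2cccc(Nc3cccc(S(F)(F)(F)(F)F)c3)c12` has not yet been measured in this assay. It differs from compound 1 by a group of 6 heavy atoms (5 fluorine, 1 sulfur; no ring) in place of a group of 4 heavy atoms (1 carbon, 3 fluorine; no ring), on an aromatic carbon. Going by the values given here, no measured step touches this exchange directly; the one step available, which added a second trifluoromethyl, lowered the number. Compound 4 is therefore expected to show only a small change, a number 5 percentage points lower from compound 1 to compound 4 (within the scatter), near the edge of the scatter. Compound 4 is estimated at 8%, within a range from 0% to 25%.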

Compound 4, a percentage reported as inhibition, at one concentration (the size of the read-out at that concentration, not a potency): 4.3%
For compound 4 the middle estimate is 3.7 percentage points above the measured one; low and high end bracket the measured number.
By their numbers in this assay, from the lowest: compounds 2, 3, 4 and 1 (each within the scatter of the next, the first and the last beyond it).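

In this assay, the exchange of trifluoromethyl for the group of 5 fluorine and 1 sulfur on this aromatic carbon gives a number 8.7 percentage points lower from compound 1 to compound 4 (within the scatter). Unlike the step that added a second trifluoromethyl, a number 13 percentage points lower from compound 1 to compound 3 (beyond the scatter), this exchange brings no change that can be told from the scatter, even though the entering group is larger. Nothing available bears on why this is so. The compounds shown leave open what an amine or a carboxylic acid on this aromatic carbon would do to the number. They also leave open whether any group here could lift it clearly beyond compound 1 at 13%.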